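Methyl to hydrogen on the ring nitrogen of compound 1

The compounds below may be only part of what the source reports. "The series", "measured", "known", "first", "only" and "open" are said of these compounds alone.

Compound 1 `Cn1c(Cc2nn(C)c(=O)c3ccccc23)nnc1SCCCCCCCC(=O)Nc1ccc(Cl)cc1Cl` gives 3900 nM in an assay on 32D cells for inhibition of interleukin-15 (Mus musculus), read by resazurin assay, with stated times of 30 min and 2.5 days, in the presence of a further agent that is not named here (a higher number here means a weaker inhibitor, a lower number a stronger inhibitor), and stands lowest of the two numbers in hand. Compound 2 `CCOC(CCn1c(Cc2nn(C)c(=O)c3ccccc23)nnc1SCCCCCCCC(=O)Nc1ccc(Cl)cc1Cl)OCC` gives 16400 nM, the step of a 4.2-fold higher number from compound 1 to compound 2 (0.62 log units; beyond the scatter) being a clear loss. Compound 3 `Cn1nc(Cc2nnc(SCCCCCCCC(=O)Nc3ccc(Cl)cc3Cl)n2CCC(=O)O)c2ccccc2c1=O` returns > 30000 nM, which is a limit of this assay and not a number (the limit of > 30000 nM in this assay, at which 1 of the 3 values shown sits). Accordingly an at least 7.6-fold higher number from compound 1 to compound 3 (0.88 log units; beyond the scatter) is known only as a floor, and an at least 1.8-fold higher number from compound 2 to compound 3 (0.26 log units; that floor lies within the scatter) likewise.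

Compound 4 `Cn1c(Cc2n[nH]c(=O)c3ccccc23)nnc1SCCCCCCCC(=O)Nc1ccc(Cl)cc1Cl` differs from compound 1 by hydrogen in place of methyl on an aromatic nitrogen. Going by the values given here, all three measured steps alter what sits on a saturated chain carbon bound to an aromatic nitrogen, a different place from the one changed here, so none of them bears directly on this move; they show only that changes to the shared core of compound 1 have so far cost potency by modest to at least modest amounts. Among the compounds with values here, with no direct precedent, a small shift is expected, if anything toward a higher number. Compound 4 is estimated at 5500 nM in this assay, within 2000 nM to 16000 nM, so the step of a 1.4-fold higher number from compound 1 to compound 4 (0.15 log units; within the scatter) is expected to stay near the scatter.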

Compound 4, half-maximal inhibitory concentration: > 30000 nM
Compound 4: no number, only a limit (the forecaster's own chance of this, stated with the estimate: 10%); middle value at least 5.4-fold (0.73 log units) away from the limit.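

In this assay compound 4 returns only a limit of the assay and not a number: the limit of > 30000 nM in this assay, at which 2 of the 4 values shown sit.

Hydrogen in place of methyl on the aromatic nitrogen of the six-membered aromatic ring with 2 nitrogen gives an at least 7.6-fold higher number from compound 1 to compound 4 (0.88 log units; beyond the scatter), the first step read at this position, since the earlier steps all lay on the saturated chain carbon bound to an aromatic nitrogen. Removing this single heavy atom is therefore enough for a loss beyond the scatter, and the true size of that loss remains unread because only a floor is available.

Open, going by these compounds, is whether ethyl or a longer chain on this nitrogen would hold or lower the number of compound 1. Also open, on these data alone, is whether a chain ending in an amine would be tolerated at this position.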